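Furan amide in place of chloro-trifluoromethyl phenyl amide

The source may hold more compounds than are shown below. What is called first, only, known or untested is meant among the compounds shown, and "the series" means these compounds.

Measured compounds in a functional assay on A375P cells (Homo sapiens) for antiproliferative activity, read by MTT assay, with a stated time of 48 h; a lower number here means a stronger inhibitor, a higher number a weaker inhibitor:
- Compound 1 `CC(=O)Nc1cccc2c(-c3cccc(NC(=O)c4ccc(C)c(C)c4)c3)ccnc12` gives only a limit, > 20000 nM.
- Compound 2 `CC(=O)Nc1cccc2c(-c3cccc(NC(=O)c4ccc(Br)c(C)c4)c3)ccnc12` gives only a limit, > 20000 nM.
- Compound 3 `CC(=O)Nc1cccc2c(-c3cccc(NC(=O)c4ccc(Cl)c(C(F)(F)F)c4)c3)ccnc12` gives 2400 nM.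

Compound 3 is therefore the only one of the three with a real number in this assay; the other two sit at the limit (the limit of > 20000 nM in this assay, at which 2 of the 3 values shown sit). Compound 4 `CC(=O)Nc1cccc2c(-c3cccc(NC(=O)c4cc(C)oc4C)c3)ccnc12` differs from compound 3 by 2,5-dimethylfuran-3-yl in place of 4-chloro-3-(trifluoromethyl)phenyl on a carbonyl carbon. Going by the values given here, two measured steps bear on this change: an at least 8.3-fold lower number from compound 1 to compound 3 (0.92 log units; beyond the scatter) and an at least 8.3-fold lower number from compound 2 to compound 3 (0.92 log units; beyond the scatter), both running toward compound 3 and both beyond the scatter. The amide of compound 4 is built from a dimethyl-bearing ring, as the 3,4-dimethylphenyl amide of compound 1 is, so the change is expected to run the opposite way: compound 4 is expected to show an 8.3-fold higher number from compound 3 to compound 4 (0.92 log units; beyond the scatter), back toward the limit. The estimate for compound 4 is 20000 nM, with a range from 5000 nM to 80000 nM, and it is thought likely that this assay will report only a limit for it.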

Compound 4, half-maximal inhibitory concentration: > 20000 nM
Compound 4 gave a limit, no number (the forecaster's own chance of this, stated with the estimate: 60%); the middle value lies on the limit itself.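

In this assay, putting 2,5-dimethylfuran-3-yl in place of 4-chloro-3-(trifluoromethyl)phenyl on the carbonyl carbon gives an at least 8.3-fold higher number from compound 3 to compound 4 (0.92 log units; beyond the scatter). The earlier compounds shown here varied only the substituents on a six-membered aromatic ring of carbon; this result extends the loss of a measurable value to a five-membered aromatic ring with one hetero atom, leaving compound 3 as the only amide of the four with a real number: the limit of > 20000 nM in this assay, at which 3 of the 4 values shown sit. The steps from compound 1 and from compound 2 to compound 4 cannot be read, since both ends of each are limits.

The compounds shown do not tell whether the chlorine, the trifluoromethyl or the two together set compound 3 apart. Nor do they show how a phenyl carrying trifluoromethyl alone, or a furan without its two methyl groups, would behave at this place.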